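A Dichlorophenyl Rearrangement: From Compound 3 to Compound 4

The source may hold more compounds than are shown below. What is called first, only, known or untested is meant among the compounds shown, and "the series" means these compounds.

Of the compounds shown here, three sharing one core have been measured in a functional assay on PC-3 cells (Homo sapiens) for inhibition, read by MTT assay, with a stated time of 72 h; on this read-out higher numbers stand for weaker inhibition and lower numbers for stronger inhibition. Compound 1 `C=CC(=O)Nc1cccc(NC(=O)CSc2nc(Nc3cccc(F)c3)c3ccccc3n2)c1` gives 5370 nM in this assay. Compound 2 `C=CC(=O)Nc1cccc(NC(=O)CSc2nc(Nc3cccc([N+](=O)[O-])c3)c3ccccc3n2)c1` gives 46300 nM in this assay. Compound 3 `C=CC(=O)Nc1cccc(NC(=O)CSc2nc(Nc3ccc(Cl)c(Cl)c3)c3ccccc3n2)c1` gives 27600 nM in this assay. Among these three numbers, compound 3 stands second highest; the step of a 5.1-fold higher number from compound 1 to compound 3 (0.71 log units; beyond the scatter) lies beyond the scatter, while the step of a 1.7-fold lower number from compound 2 to compound 3 (0.22 log units; within the scatter) does not, so compound 3 and compound 2 cannot be told apart on these data.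

Compound 4 `C=CC(=O)Nc1cccc(NC(=O)CSc2nc(Nc3ccc(Cl)cc3Cl)c3ccccc3n2)c1` is yet to be measured in this assay. The change from compound 3 is 2,4-dichlorophenyl in place of 3,4-dichlorophenyl on a nitrogen on an aromatic ring. Of the measured steps, a 5.1-fold higher number from compound 1 to compound 3 (0.71 log units; beyond the scatter) and a 1.7-fold lower number from compound 2 to compound 3 (0.22 log units; within the scatter) both concern the group on that same nitrogen, but each of them exchanges one substituent pattern for another set of atoms, whereas compound 4 keeps the same atoms and moves one chlorine. For the measured compounds named here, no measured pair shows what such a move does here. The step of a 1.1-fold higher number from compound 3 to compound 4 (0.04 log units; within the scatter) is therefore expected to be none beyond the scatter in this assay. Compound 4 is estimated at 30000 nM in this assay, with a range from 8000 nM to 100000 nM.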

Compound 4, half-maximal inhibitory concentration: 25700 nM
Estimate against measurement, compound 4: 1.2-fold (0.07 log units) above; the range from low to high includes it.
By their numbers in this assay, from the lowest: compound 1; then compounds 4, 3 and 2 (each within the scatter of the next).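

In this assay, for the compounds shown here, moving one chlorine on the ring carried by the nitrogen gives a 1.1-fold lower number from compound 3 to compound 4 (0.03 log units; within the scatter), so 2,4-dichlorophenyl and 3,4-dichlorophenyl cannot be told apart here, and this is the first measured pair at this position with the same atoms joined differently. Compound 4 also cannot be told apart from compound 2, with a 1.8-fold lower number from compound 2 to compound 4 (0.26 log units; within the scatter), while a 4.8-fold higher number from compound 1 to compound 4 (0.68 log units; beyond the scatter) confirms that the three groups other than 3-fluorophenyl sit together and that compound 1 alone stands apart, its number lower than each of the others beyond the scatter. Nothing measured beyond these numbers is at hand to account for any of these steps.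

The compounds shown leave open whether a single chlorine, a methoxy group or an amine in place of the fluoro group would stay with compound 1 or join the other three. They also leave open whether moving the fluorine of compound 1 around its ring would change the number, as moving a chlorine did not between compound 3 and compound 4.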